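The compounds below may be only part of what the source reports. "The series", "measured", "known", "first", "only" and "open" are said of these compounds alone.

Of the compounds shown here, two share one core and have been measured so far. Compound 1 `Cc1cc(Nc2cc(-c3ccccc3)[nH]n2)n2nc(SCc3c(Cl)cccc3Cl)nc2n1` gives 5280 nM in a functional assay on MGC-803 cells (Homo sapiens) for inhibition, read by MTT assay, with a stated time of 72 h (on this read-out lower numbers stand for stronger inhibition and higher numbers for weaker inhibition), the highest of the two numbers, though its nearest neighbour, compound 2 `Cc1cc(Nc2cc(-c3ccccc3)[nH]n2)n2nc(SCc3cccc(Br)c3)nc2n1`, gives 4820 nM in this assay and lies within the scatter. Within the data shown here, the only measured step is a 1.1-fold lower number from compound 1 to compound 2 (0.04 log units; within the scatter). Compound 3 `Cc1cc(Nc2cc(-c3ccccc3)[nH]n2)n2nc(SCc3ccc(C(F)(F)F)cc3)nc2n1` is not yet measured; it differs from compound 1 by 4-(trifluoromethyl)phenyl in place of 2,6-dichlorophenyl on a saturated chain carbon bound to a sulfur. Because a 1.1-fold lower number from compound 1 to compound 2 (0.04 log units; within the scatter) stayed within the scatter, the expected step is a 1.1-fold lower number from compound 1 to compound 3 (0.02 log units; within the scatter), nothing beyond the scatter. Compound 3 is therefore estimated at 5000 nM, with a range from 2300 nM to 11000 nM.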

Compound 3, half-maximal inhibitory concentration: 3520 nM
Estimate against measurement, compound 3: 1.4-fold (0.15 log units) above, and the stated range covers the measured number.
By their numbers in this assay, from the lowest: compounds 3, 2 and 1 (each within the scatter of the next).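

Placing 4-(trifluoromethyl)phenyl on the saturated chain carbon bound to a sulfur gives a 1.5-fold lower number from compound 1 to compound 3 (0.18 log units; within the scatter), and against 3-bromophenyl it gives a 1.4-fold lower number from compound 2 to compound 3 (0.14 log units; within the scatter). Three differently substituted phenyl groups at this position, including one with more heavy atoms than 2,6-dichlorophenyl, therefore cannot be told apart on these numbers. Nothing available explains this result.

The compounds shown leave open whether a group other than a substituted benzyl would move the number beyond the scatter. An amine or carboxylic acid on the phenyl ring, or a longer chain in place of the benzyl group, could test this.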